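This account rests on a few compounds, and the source may have more. Where it says the series, first, only, none or still open, it means among the compounds named here.

In an assay on cells for agonist activity at vitamin D3 receptor (Homo sapiens), read by microscopy (a higher number here means that more compound is needed for the effect, a lower number that less compound is needed), compound 2 `CCn1cc(C(CC)(CC)c2ccc(C#CC(O)(CC)CC)c(C)c2)cc1C(=O)OCCO` gives 12.6 nM. Among the measured compounds shown here, the only other number so far comes from compound 1 `CCn1c(C(=O)NCC(=O)O)ccc1C(CC)(CC)c1ccc(C#CC(O)(CC)CC)c(C)c1`, which gives 9.36 nM, within the scatter of compound 2, so the two are not told apart. Compound 3 `CCn1cc(C(CC)(CC)c2ccc(C#CC(O)(CC)CC)c(C)c2)cc1C(=O)N[C@H](C(=O)O)C(C)C` differs from compound 2 by (1-carboxy-2-methylpropyl)amino in place of 2-hydroxyethoxy on a carbonyl carbon. For the measured compounds named here, no measured pair isolates this change, so its effect is not known from the data. The step from compound 2 to compound 3 is expected to be small, leaning toward a lower number, because compound 1 gives 9.36 nM and the estimate reads a 1.6-fold lower number from compound 2 to compound 3 (0.20 log units; within the scatter). Compound 3 is therefore expected near 8 nM, within 3 nM to 25 nM.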

Compound 3, half-maximal effective concentration: 12.7 nM
For compound 3 the middle estimate is 1.6-fold (0.20 log units) below the measured one; the range from low to high includes it.
By their numbers in this assay, from the lowest: compounds 1, 2 and 3 (each within the scatter of the next).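

Swapping 2-hydroxyethoxy for (1-carboxy-2-methylpropyl)amino on a carbonyl carbon in this assay gives a 1.0-fold higher number from compound 2 to compound 3 (0.00 log units; within the scatter) and so leaves compound 2 and compound 3 not told apart. This position thus carries either the small (2-hydroxyethoxy)carbonyl or the larger (1-carboxy-2-methylpropyl)carbamoyl, with its defined stereocentre, without a readable difference in the number. Nothing available explains this result. On these data alone, what stays open is whether a plain amine or a longer carbon chain on this carbonyl carbon would be told apart from compound 2. Also open, as far as these compounds go, is what the opposite stereocentre would give.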